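Ethoxymethyl to isopropoxymethyl: little change expected

The source may report more compounds than this note shows. Statements on the series, on what has been measured and on what is new or still open speak of the compounds shown alone.

Of the compounds shown here, two carry numbers so far. Within the data shown here, compound 1 (`CC(C)OCc1cc(CN2CCCCC2)c(O)c2ncccc12`) gives 4370 nM in a functional assay on MES-SA/Dx5 cells (Homo sapiens) for inhibition, with a stated time of 72 h, in the presence of a further agent that is not named here (on this read-out higher numbers stand for weaker inhibition and lower numbers for stronger inhibition), as the first reading of the series. Compound 2 (`CCOCc1cc(CN2CCC(C)CC2)c(O)c2ncccc12`) gives 3020 nM in this assay and so stands within the scatter of compound 1. Among the measured compounds shown here, no measured pair differs in one place only, so no measured step is available as a guide.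

Compound 3 (`CC1CCN(Cc2cc(COC(C)C)c3cccnc3c2O)CC1`) is one change away from compound 2: methyl in place of hydrogen on a saturated chain carbon bound to an oxygen on a saturated carbon and a saturated chain carbon, which reads as ethoxymethyl to isopropoxymethyl. No step beyond the scatter is expected in this assay, in either direction. This expectation rests on how close the two measured values are, with compound 1 at 4370 nM and compound 2 at 3020 nM on the same read-out. The expected change is a 1.1-fold higher number from compound 2 to compound 3 (0.04 log units; within the scatter) and stays within the scatter. For compound 3 the estimated value is 3300 nM with an expected range from 1600 nM to 6500 nM in this read-out.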

Compound 3, half-maximal inhibitory concentration: 2140 nM
Beside the measured number, compound 3's estimate is 1.5-fold (0.19 log units) above it; the measured number falls inside the stated range.
By their numbers in this assay, from the lowest: compounds 3, 2 and 1 (each within the scatter of the next, the first and the last beyond it).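

In this assay, the ethoxymethyl to isopropoxymethyl change is now measured as a single step, a 1.4-fold lower number from compound 2 to compound 3 (0.15 log units; within the scatter), so methyl in place of hydrogen on this saturated chain carbon leaves the read-out within the usual scatter. Among these compounds, the second methyl change, on a saturated ring carbon, gives a 2.0-fold lower number from compound 1 to compound 3 (0.31 log units; beyond the scatter), a modest step that is the first to pass beyond the scatter, though only just. The two steps sit at different places on the molecule, and nothing measured for this series bears on why the numbers fall as they do.

On these data alone, whether the tolerance at the chain carbon extends past a single methyl remains open, for instance with a longer chain such as butyl, or with a carboxylic acid or an amine at the end of the ether chain. As far as these compounds go, on the saturated ring, it is also open whether the methyl step would hold with ethoxymethyl in place of isopropoxymethyl, or how a hydroxyl on that ring carbon would read.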